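The source may report more compounds than this note shows. Statements on the series, on what has been measured and on what is new or still open speak of the compounds shown alone.

Compound 1 `CCc1ccccc1NS(=O)(=O)c1ccc(N2CCNC2=O)cc1` gives 180 nM in a functional assay on M21 cells (Homo sapiens) for antiproliferative activity, read by sulforhodamine B assay, with a stated time of 48 h; a higher number here means a weaker inhibitor, a lower number a stronger inhibitor. Compound 2 `O=C1NCCN1c1ccc(S(=O)(=O)Nc2cccc(Br)c2)cc1` gives 59 nM. Compound 3 `Cc1ccccc1NS(=O)(=O)c1ccc(N2CCNC2=O)cc1` gives 150 nM.

Compound 3 has the second highest of the three numbers: its gap to compound 1 is within the scatter, while a 2.5-fold higher number from compound 2 to compound 3 (0.41 log units; beyond the scatter) is beyond it. Compound 4 `O=C1NCCN1c1ccc(S(=O)(=O)Nc2ccc(F)c(F)c2)cc1` is compound 3 with 3,4-difluorophenyl in place of 2-methylphenyl on a sulfonamide nitrogen. For the measured compounds named here, two measured steps bear on this change, both swaps of the aryl group on the sulfonamide nitrogen: a 3.1-fold lower number from compound 1 to compound 2 (0.48 log units; beyond the scatter) and a 2.5-fold higher number from compound 2 to compound 3 (0.41 log units; beyond the scatter). In both, the 3-bromophenyl compound gave the lower number. A second halogen-bearing aryl is therefore expected to give a modestly lower number than compound 3, about a 1.8-fold lower number from compound 3 to compound 4 (0.25 log units; within the scatter), though a gap within the scatter cannot be excluded. Compound 4 is estimated at 85 nM, between 40 nM and 180 nM.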

Compound 4, half-maximal inhibitory concentration: 220 nM
For compound 4 the middle estimate is 2.6-fold (0.41 log units) below the measured one, and the stated range ends below it.
By their numbers in this assay, from the lowest: compound 2; then compounds 3, 1 and 4 (each within the scatter of the next).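

In this assay, the 3,4-difluorophenyl group does not match 3-bromophenyl on the sulfonamide nitrogen: a 3.7-fold higher number from compound 2 to compound 4 (0.57 log units; beyond the scatter) is the largest step among these compounds, so a halogen-bearing aryl group does not by itself bring the lower number. Both a 1.5-fold higher number from compound 3 to compound 4 (0.17 log units; within the scatter) and a 1.2-fold higher number from compound 1 to compound 4 (0.09 log units; within the scatter) leave compound 4 level with the 2-methylphenyl and 2-ethylphenyl compounds. Nothing available here accounts for this gap. On these data alone, it remains open what 3-chlorophenyl or 4-bromophenyl would give, and whether an aryl group carrying an amine or a carboxylic acid would fit this series.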